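The source may report more compounds than this note shows. Statements on the series, on what has been measured and on what is new or still open speak of the compounds shown alone.

Compound 1, `CCCCCCCCCCN1NN=C(NC(=O)Nc2c(C(C)C)cccc2C(C)C)N1`: 14 nM
Compound 2, `CCCCCCCCCCCN1NN=C(NC(=O)Nc2c(C(C)C)cccc2C(C)C)N1`: 9 nM

Of the compounds shown here, two have been measured in an assay on microsomes from intestine for inhibition of acyl-CoA:cholesterol acyltransferase (Oryctolagus cuniculus) (a lower number here means a stronger inhibitor, a higher number a weaker inhibitor), and both carry the same core with a long saturated chain on the ring nitrogen. Among the measured compounds shown here, compound 2 gives the smaller of the two numbers, but the gap to compound 1 is within the scatter: the single measured step reads a 1.6-fold lower number from compound 1 to compound 2 (0.19 log units; within the scatter), that is, one more chain carbon made no difference that can be trusted.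

Compound 3, `CCCCCCCCCCCCCN1NN=C(NC(=O)Nc2c(C(C)C)cccc2C(C)C)N1`, takes the same direction one stage further. The change from compound 2 is ethyl in place of hydrogen on a saturated chain carbon, ten or more bonds along the chain from an amine nitrogen in a ring. For the measured compounds named here, the only step that bears on it is the one from compound 1 to compound 2, and that step lay within the scatter, so the present data give no ground to expect the longer chain to move this assay beyond the scatter in either direction. The expected step is a 1.1-fold lower number from compound 2 to compound 3 (0.05 log units; within the scatter). Compound 3 is therefore estimated at 8 nM, with a range from 3 nM to 20 nM.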

Compound 3, half-maximal inhibitory concentration: 9 nM
Beside the measured number, compound 3's estimate is 1.1-fold (0.05 log units) below it; the range from low to high includes it.
By their numbers in this assay, from the lowest: compounds 2, 3 and 1 (each within the scatter of the next).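

In this assay, ethyl in place of hydrogen on a saturated chain carbon, ten or more bonds along the chain from an amine nitrogen in a ring, gives no change at the digits printed from compound 2 to compound 3 (within the scatter) and so adds a second step at this place that stays within the scatter. Read across the whole series, propyl in place of hydrogen at the same place gives a 1.6-fold lower number from compound 1 to compound 3 (0.19 log units; within the scatter), so even the largest addition among these three compounds cannot be told apart from repeated measurement, and the three chains show no trend with length that can be trusted. The data shown offer no information on what lies behind this flat result.

Going by these compounds, what remains open is how far this tolerance reaches: a much shorter chain, such as butyl, or a much longer one might move the number beyond the scatter, and these three compounds cannot mark either limit. On these data alone, it is also open whether the far end of the chain accepts something other than plain carbon and hydrogen, such as a terminal amine, a carboxylic acid or a hydroxyl group.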